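The compounds below may be only part of what the source reports. "The series", "measured", "known", "first", "only" and "open" are said of these compounds alone.

Working notes on a series of positive allosteric modulators tested in an assay on HEK293 cells for positive allosteric modulation of metabotropic glutamate receptor 2 (Rattus norvegicus), read by thallium flux, with a stated time of 2.5 min; a lower number here means that less compound is needed, a higher number that more compound is needed for the effect.

Three compounds have numbers. Compound 1, `COc1cc(C(=O)O)ccc1OCCCCOc1ccc(C(=O)CC(C)(C)C)c(O)c1C`, gives 47 nM in this assay. Compound 2, `CCC(=O)c1ccc(OCCCCOc2ccc(F)c(C(=O)O)c2)c(C)c1O`, gives 124 nM in this assay. Compound 3, `Cc1c(OCCCCOc2ccccc2C(=O)O)ccc(C(=O)CC2CCCC2)c1O`, gives 335 nM in this assay. Compound 2 thus stands second highest of the three, with compound 1 at a lower number and compound 3 at a higher number, both differences beyond the usual scatter. Going by the values given here, no pair of measured compounds differs in only one place, so no single-point step can be read from the measured set; the three compounds vary at once in the ketone chain and in the benzoic acid substitution.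

Compound 4, `CCCC(=O)c1ccc(OCCCCOc2ccc(F)c(C(=O)O)c2)c(C)c1O`, is not yet measured. It differs from compound 2 by methyl in place of hydrogen on a saturated chain carbon, two bonds along the chain from a carbonyl carbon.

Among the compounds with values here, since no comparable step is available among the measured compounds, and since the larger ketone chains of compound 1 and compound 3 point in opposite directions from compound 2, the change from propanoyl to propylcarbonyl is expected to produce a step of a 1.1-fold lower number from compound 2 to compound 4 (0.05 log units; within the scatter) of no more than the scatter, in either direction. Compound 4 is accordingly expected to give about 110 nM in this assay, within a range of 45 nM to 270 nM.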

Compound 4, half-maximal effective concentration: 74 nM
For compound 4 the middle estimate is 1.5-fold (0.17 log units) above the measured one; the range from low to high includes it.
By their numbers in this assay, from the lowest: compounds 1, 4 and 2 (each within the scatter of the next, the first and the last beyond it); then compound 3.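

Going by these compounds alone, with the first single-place comparison, adding methyl in place of hydrogen on a saturated chain carbon, two bonds along the chain from a carbonyl carbon, gives in this assay a 1.7-fold lower number from compound 2 to compound 4 (0.22 log units; within the scatter) and so does not separate the two compounds. The earlier compounds shown here could not show this, as they vary at once in the ketone chain and in the benzoic acid substitution, whereas here the change from propanoyl to propylcarbonyl stands alone and the rest of the structure is held fixed. No measurement available bears on this step, and no account of it is offered.

Going by these compounds, whether a longer straight chain, or an amine or a hydroxyl group on this same chain carbon, would also stay within the scatter of compound 2 remains open. The step also rests on a single pair carrying one benzoic acid substitution, so the compounds shown cannot tell whether the same change would give a step of similar size on the cores of compound 1 or compound 3.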